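Swapping a nitro for a methyl on a urea ester

The source may report more compounds than this note shows. Statements on the series, on what has been measured and on what is new or still open speak of the compounds shown alone.

Three compounds share a urea linked to a phenyl ester. Compound 1 `O=C(Nc1ccc(OC(=O)c2cc3cc([N+](=O)[O-])ccc3s2)cc1)Nc1ccc(Oc2ccccc2)cc1` gives 25200 nM in a functional assay on A549 cells (Homo sapiens) for antiproliferative activity, read by MTT assay, with a stated time of 48 h; a higher number here means a weaker inhibitor, a lower number a stronger inhibitor. Compound 2 `O=C(Nc1ccccc1)Nc1ccc(OC(=O)c2ccccc2)cc1` gives 81200 nM, and compound 3 `O=C(Nc1ccccc1)Nc1ccc(OC(=O)c2ccc([N+](=O)[O-])cc2)cc1` gives 120000 nM, the highest of the three numbers, with compound 1 the furthest away. The step of a 1.5-fold higher number from compound 2 to compound 3 (0.17 log units; within the scatter) shows that nitro versus hydrogen at this spot barely moves the result. Compound 4 `Cc1ccc(C(=O)Oc2ccc(NC(=O)Nc3ccccc3)cc2)cc1` carries the change (methyl in place of nitro on an aromatic carbon), placed para to a large group. Since exchanging hydrogen for nitro stayed within the scatter, replacing nitro with methyl is expected to give a step of a 1.3-fold lower number from compound 3 to compound 4 (0.10 log units; within the scatter), with no confident direction. Compound 4 is therefore estimated at 95000 nM, within a range of 35000 nM to 250000 nM.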

Compound 4, half-maximal inhibitory concentration: 18900 nM
Beside the measured number, compound 4's estimate is 5.0-fold (0.70 log units) above it, and the stated range ends above it.
By their numbers in this assay, from the lowest: compounds 4 and 1 (each within the scatter of the next); then compounds 2 and 3 (each within the scatter of the next).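

This position is not indifferent to what sits on it: in this assay, methyl in place of nitro gives a 6.3-fold lower number from compound 3 to compound 4 (0.80 log units; beyond the scatter), and methyl in place of hydrogen gives a 4.3-fold lower number from compound 2 to compound 4 (0.63 log units; beyond the scatter), both beyond the scatter, whereas nitro in place of hydrogen stayed within it. Of the three groups tried here, only methyl separates from the others. Nothing available explains this difference. On these data alone, whether an amine, a carboxylic acid or a longer chain at this spot would behave like methyl remains open, as does whether methyl would have the same effect on the core of compound 1.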